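The source may hold more compounds than are shown below. What is called first, only, known or untested is meant among the compounds shown, and "the series" means these compounds.

Series notes. Compound 1 `CCCc1nc2cccc(C(=O)O)c2n1Cc1ccc(-c2ccccc2-c2noc(O)n2)cc1`, compound 2 `CCCCc1nc2cccc(C(=O)O)c2n1Cc1ccc(-c2ccccc2-c2noc(O)n2)cc1` and compound 3 `CSc1nc2cccc(C(=O)O)c2n1Cc1ccc(-c2ccccc2-c2noc(O)n2)cc1` have been run in a functional assay on the whole organism for inhibition, with Rattus norvegicus as the target, with a stated time of 7 h, at a dose of 1 mg/kg by the oral route; a higher number here means more inhibition at the dose given (going by the name of the read-out), a lower number less inhibition. In this assay compound 1 gives 88%, compound 2 gives 64% and compound 3 gives 100%. Compound 3 stands highest of the three, with both of its steps to the others beyond the scatter: a number 12 percentage points higher from compound 1 to compound 3 (beyond the scatter), which is the core difference (methylsulfanyl in place of propyl on an aromatic carbon), and a number 36 percentage points higher from compound 2 to compound 3 (beyond the scatter). Within the core of compound 1, the change methyl in place of hydrogen on a saturated chain carbon, three bonds along the chain from an aromatic carbon produced a number 24 percentage points lower from compound 1 to compound 2 (beyond the scatter).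

Compound 4 `CCSc1nc2cccc(C(=O)O)c2n1Cc1ccc(-c2ccccc2-c2noc(O)n2)cc1` is not yet measured in this assay. It differs from compound 3 by methyl in place of hydrogen on a saturated chain carbon bound to a sulfur. This is the same kind of change as that from compound 1 to compound 2, though the place is not the same: there the saturated chain carbon sat three bonds along the chain from an aromatic carbon, here it is bound to a sulfur. The step expected from compound 3 to compound 4 in this assay is a number 16 percentage points lower from compound 3 to compound 4 (beyond the scatter), a downward move resting on the step of a number 24 percentage points lower from compound 1 to compound 2 (beyond the scatter) and on the value of compound 3, 100%, which leaves no room upward. Compound 4 is estimated at 84%, expected to fall between 64% and 100%.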

Compound 4, a percentage reported as inhibition, in the whole organism at one dose (the size of the read-out at that dose, not a potency): 100%
Beside the measured number, compound 4's estimate is 16 percentage points below it; the range from low to high includes it.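

Adding the methyl does not give the same step on the two cores in this assay, where the new step reads no change at the digits printed from compound 3 to compound 4 (within the scatter), so the drop seen on lengthening propyl to butyl does not carry over to the change from methylsulfanyl to ethylsulfanyl: the same change on two cores in this assay, a number 24 percentage points lower (beyond the scatter) from compound 1 to compound 2 and no change at the digits printed (within the scatter) from compound 3 to compound 4, 24 percentage points apart, beyond the scatter of two such steps

The sulfur-linked compounds still stand clear of the chain-linked ones, with a number 36 percentage points higher from compound 2 to compound 4 (beyond the scatter) and a number 12 percentage points higher from compound 1 to compound 4 (beyond the scatter). This does not show that the methyl is without effect on this core: compound 4 gives 100% at a single dose, a value that allows no upward move and could mask a difference from compound 3, and two pairs of compounds set no rule for other cores.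

The compounds shown leave open how propylsulfanyl or butylsulfanyl would read, and so whether a longer chain on the sulfur brings the drop seen with butyl. They also leave open whether a lower dose would separate compound 3 from compound 4.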